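This account rests on a few compounds, and the source may have more. Where it says the series, first, only, none or still open, it means among the compounds named here.

In a functional assay on THP-1 cells (Homo sapiens) for inhibition, read by sulforhodamine B assay, with a stated time of 48 h, tested at 50 uM (on this read-out lower numbers stand for less inhibition of growth and higher numbers for more inhibition of growth at the one concentration tested), compound 1 (`COc1ccc(/C=C/C(=O)/C=C/c2ccc(OCc3cn(CCCCOc4cc(=O)oc5ccccc45)nn3)c(OC)c2)cc1OC`) gives 59% and compound 2 (`COc1cc(/C=C/C(=O)/C=C/c2ccco2)ccc1OCc1cn(CCCOc2cc(=O)oc3ccccc23)nn1`) gives 57% while compound 3 (`COc1cccc(/C=C/C(=O)/C=C/c2ccc(OCc3cn(CCCCOc4cc(=O)oc5ccccc45)nn3)c(OC)c2)c1`) gives 47% at the one concentration tested. Compound 3 thus lies within the scatter of compound 2 and beyond the scatter under compound 1. Compound 4 (`COc1cc(/C=C/C(=O)/C=C/c2ccccc2)ccc1OCc1cn(CCCCOc2cc(=O)oc3ccccc23)nn1`) has hydrogen in place of methoxy on an aromatic carbon, 3-methoxyphenyl to phenyl (hydrogen in place of methoxy on an aromatic carbon). One measured step is the same kind of exchange and is modest (a number 12 percentage points lower from compound 1 to compound 3 (beyond the scatter)). Within the data shown here, compound 2 differs from the others in more than one place and gives no such step. A somewhat smaller step in the same direction is expected in this assay (a number 9 percentage points lower from compound 3 to compound 4 (within the scatter)). For compound 4 the estimate is 38% with an expected range from 26% to 50% in this read-out.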

Compound 4, percent growth inhibition at one concentration: 36%
The estimate for compound 4 lay 2 percentage points above the measured number, within the range that was stated.
By their numbers in this assay, from the lowest: compound 4; then compounds 3, 2 and 1 (each within the scatter of the next, the first and the last beyond it).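

In this assay the change from 3-methoxyphenyl to phenyl gives a number 11 percentage points lower from compound 3 to compound 4 (beyond the scatter) and so shows that this methoxy also counts, in the same direction as the step already seen, a number 12 percentage points lower from compound 1 to compound 3 (beyond the scatter) for the other methoxy. With both methoxy groups gone, the whole change reads a number 23 percentage points lower from compound 1 to compound 4 (beyond the scatter) so that compound 1, compound 3 and compound 4 fall in turn with each methoxy lost. Open, from the compounds shown here alone, is what a hydroxyl or an amine on this ring would give in place of methoxy. The data shown hold nothing that explains these steps.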